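The source may hold more compounds than are shown below. What is called first, only, known or untested is meant among the compounds shown, and "the series" means these compounds.

In a functional assay on NCI-H2122 cells (Homo sapiens) for inhibition, read by microscopy, with a stated time of 10 days (a higher number here means a weaker inhibitor, a lower number a stronger inhibitor), compound 1 `COc1ccc(-c2nn(C)c3c2C(c2ccc(F)cc2)C(C#N)=C(N)O3)cc1OC` gives > 10000 nM, which is a limit of the assay rather than a number. Compound 2 `COc1ccc(-c2nn(-c3ccccc3)c3c2C(c2ccc(F)cc2)C(C#N)=C(N)O3)cc1OC` in this assay gives 7600 nM. The change between them is phenyl in place of methyl on an aromatic nitrogen, and it made an at least 1.3-fold lower number from compound 1 to compound 2 (0.11 log units; that floor lies within the scatter). Because of the limit of > 10000 nM in this assay, at which 2 of the 3 values shown sit, that step is known only as a floor. Compound 3 `COc1ccc(C2C(C#N)=C(N)Oc3c2c(-c2ccccc2)nn3C)cc1` has a different core; the difference between the two cores is not broken down here. In this assay compound 3 gives > 10000 nM, again a limit of the assay. Compound 4 `COc1ccc(C2C(C#N)=C(N)Oc3c2c(-c2ccccc2)nn3-c2ccccc2)cc1` has not yet been measured; it differs from compound 3 by phenyl in place of methyl on an aromatic nitrogen. Among the measured compounds shown here, this is the same kind of change as the one between compound 1 and compound 2, though the surroundings differ: in compound 1 the place is two ring bonds from the ring atom that bears a 3,4-dimethoxyphenyl group, whereas in compound 3 it is two ring bonds from the ring atom that bears a phenyl group. A modest step is expected, an at least 1.1-fold lower number from compound 3 to compound 4 (0.04 log units; that floor lies within the scatter), resting on the size of an at least 1.3-fold lower number from compound 1 to compound 2 (0.11 log units; that floor lies within the scatter). Compound 4 is therefore expected to give about 9000 nM in this assay, with a fair chance that only a limit is reported again.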

Compound 4, half-maximal inhibitory concentration: 3100 nM
Compound 4: the middle estimate sits 2.9-fold (0.46 log units) above what was measured; the measured number lies below the stated range.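

In this assay, phenyl in place of methyl on an aromatic nitrogen gives an at least 3.2-fold lower number from compound 3 to compound 4 (0.50 log units; beyond the scatter), so on this core the change clearly goes with a lower number, and the core of compound 1 points the same way, though there the floor stays within the scatter. Each step is known only as a floor, because compound 1 and compound 3 both stand at a limit of the assay rather than at a number: the limit of > 10000 nM in this assay, at which 2 of the 4 values shown sit. The direction therefore carries from one core to the other in these two pairs, but whether the size carries as well cannot be said: the same change on two cores in this assay, an at least 1.3-fold lower number (0.11 log units; that floor lies within the scatter) from compound 1 to compound 2 and an at least 3.2-fold lower number (0.50 log units; beyond the scatter) from compound 3 to compound 4; the limit leaves it open whether they differ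

Among the compounds shown, only methyl and phenyl stand on this nitrogen, so it stays open how a longer chain, a benzyl group or a phenyl ring carrying an amine or a carboxylic acid would behave. Among the compounds shown here, also open is which of the differences between the two cores matters for the size of the step, as no pair here separates them.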